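Swapping a dicyanobenzyl ether for a cyanopyridinylmethyl ether

The source may hold more compounds than are shown below. What is called first, only, known or untested is meant among the compounds shown, and "the series" means these compounds.

Compound 1, `C[C@@H]1CN(c2nnc(C(F)(F)F)o2)CCN1c1ncc(OCc2ccc(OS(C)(=O)=O)cc2F)cn1`, in a functional assay on HEK293S cells for agonist activity at Glucose-dependent insulinotropic receptor (Mus musculus), read by HTRF and cAMP accumulation, with a stated time of 45 min (on this read-out higher numbers stand for an effect only at larger amounts of compound and lower numbers for an effect already at smaller amounts), gives 42 nM.
Compound 2, `C[C@@H]1CN(c2nnc(C(F)(F)F)o2)CCN1c1ncc(OCc2ccc(C#N)cc2C#N)cn1`, in this assay gives 72 nM.

Within the data shown here, compound 2 stands at the higher of the two numbers so far, but the step of a 1.7-fold higher number from compound 1 to compound 2 (0.23 log units; within the scatter) lies within the scatter, so the two measured compounds cannot be separated on this read-out. Compound 3, `C[C@@H]1CN(c2nnc(C(F)(F)F)o2)CCN1c1ncc(OCc2ccncc2C#N)cn1`, differs from compound 2 in one place: 3-cyanopyridin-4-yl in place of 2,4-dicyanophenyl on a saturated chain carbon bound to an oxygen on an aromatic ring. Among the measured compounds shown here, only one measured step exists, a 1.7-fold higher number from compound 1 to compound 2 (0.23 log units; within the scatter), and it concerns the same part of the molecule, the group on the saturated chain carbon bound to the oxygen on the aromatic ring; it was small. It does not, however, involve the exchange of a carbon-only ring for a ring with one hetero atom, so it guides the present change only loosely. Compound 3 is therefore expected to show a 1.4-fold higher number from compound 2 to compound 3 (0.14 log units; within the scatter), a step that need not exceed the scatter. Compound 3 is estimated at 100 nM, with a range from 30 nM to 350 nM.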

Compound 3, half-maximal effective concentration: 436 nM
For compound 3 the middle estimate is 4.4-fold (0.64 log units) below the measured one; measured number outside the range, above it.
By their numbers in this assay, from the lowest: compounds 1 and 2 (each within the scatter of the next); then compound 3.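

In this assay the group on the saturated chain carbon bound to an oxygen on an aromatic ring can move the number beyond the scatter, which the earlier step at this place, a 1.7-fold higher number from compound 1 to compound 2 (0.23 log units; within the scatter), did not show. Exchanging 2,4-dicyanophenyl for 3-cyanopyridin-4-yl gives a 6.1-fold higher number from compound 2 to compound 3 (0.78 log units; beyond the scatter), and exchanging 2-fluoro-4-((methylsulfonyl)oxy)phenyl for it gives a 10-fold higher number from compound 1 to compound 3 (1.02 log units; beyond the scatter), so compound 3 stands apart from both earlier compounds. The exchange removes one triple bond and brings a hetero atom into the ring, while the count of hydrogen-bond acceptors stays the same, so that count does not follow the step and the two structural differences cannot be separated here. No measurement is available that accounts for this step.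

Going by these compounds, a cyanophenyl group carrying a single nitrile on a carbon-only ring would show whether the step follows the lost nitrile or the ring nitrogen, and that remains open. Also open, on these data alone, is how a 2,4-dicyanopyridinyl group, or an amine or a carboxylic acid on the same ring, would read out at this place.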